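A few compounds are considered here, and "the series" means these few. Any claim that something is new, unique, unknown or untested is made for them only; others in the source may bear on it.

Measured so far:
compound 1 `CS(=O)(=O)Cc1cccc(C#Cc2cc(Cl)ccc2OCC(=O)O)c1` gives 48 nM in an assay on CHO cells for displacement of a labelled ligand from prostaglandin D2 receptor 2 (Homo sapiens), read by scintillation counting; a lower number here means a stronger inhibitor, a higher number a weaker inhibitor
compound 2 `CCCS(=O)(=O)c1ccc(C)c(C#Cc2cc(Cl)ccc2OC(C)C(=O)O)c1` gives 1.2 nM in this assay

Of these two numbers, compound 1 has the higher one, so it is the weaker inhibitor of the pair, and compound 2 is the stronger by a margin well beyond the scatter. Compound 3 `CCCS(=O)(=O)c1cccc(C#Cc2cc(Cl)ccc2OCC(=O)O)c1` has not yet been measured. It differs from compound 1 in one place: propylsulfonyl in place of (methylsulfonyl)methyl on an aromatic carbon. Compound 3 thus carries the propylsulfonyl group that compound 2 also carries, but compound 2 differs from compound 3 elsewhere too, so the two do not form a single-change pair. Among the compounds with values here, no measured pair isolates this change, and the size of the step in this assay is therefore uncertain; a move to a lower number, beyond the scatter, is expected rather than no change. Compound 3 is expected to give 10 nM, within 3 nM to 40 nM. That estimate corresponds to an expected step of a 4.8-fold lower number from compound 1 to compound 3 (0.68 log units; beyond the scatter).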

Compound 3, inhibition constant: 9 nM
Estimate against measurement, compound 3: 1.1-fold (0.05 log units) above; the measured number falls inside the stated range.
By their numbers in this assay, from the lowest: compound 2; then compound 3; then compound 1.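

Within the data shown here, compound 1 and compound 3 differ in one place only, so this pair gives the first clean reading of a change on this aromatic carbon: in this assay, propylsulfonyl in place of (methylsulfonyl)methyl gives a 5.3-fold lower number from compound 1 to compound 3 (0.73 log units; beyond the scatter). The number therefore responds to the group at this position, even with the rest of the molecule held fixed, and the modest step shows that propylsulfonyl alone does not bring compound 3 down to the value of compound 2. Nothing measured here gives a reason for the step.

The compounds shown do not separate the effect of the sulfonyl group sitting directly on the ring from that of the chain on it, which a plain methylsulfonyl or a longer butylsulfonyl group could help to resolve. It also remains open which of the other differences in compound 2 account for its lower number.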